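Trifluoromethyl in place of hydrogen on the phenyl ring

A few compounds are considered here, and "the series" means these few. Any claim that something is new, unique, unknown or untested is made for them only; others in the source may bear on it.

Three compounds on the shared core have numbers in an assay on isolated protein for agonist activity at Free fatty acid receptor 1 (Homo sapiens); on this read-out higher numbers stand for an effect only at larger amounts of compound and lower numbers for an effect already at smaller amounts. Compound 1 `CC#CC(CC(=O)O)c1ccc(OCc2ccc3nc(-c4ccc(C5CCCCC5)cc4)cn3c2)cc1` gives 417 nM in this assay. Compound 2 `CC#CC(CC(=O)O)c1ccc(OCc2ccc3nc(-c4ccc(C)cc4)cn3c2)cc1` gives 507 nM. Compound 3 `CC#CC(CC(=O)O)c1ccc(OCc2ccc3nc(-c4ccccc4)cn3c2)cc1` gives 979 nM, the highest of the three numbers; its gap to compound 2 is within the scatter and its gap to compound 1 is beyond it. Between the first two, a 1.2-fold higher number from compound 1 to compound 2 (0.08 log units; within the scatter).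

Compound 4 `CC#CC(CC(=O)O)c1ccc(OCc2ccc3nc(-c4ccc(C(F)(F)F)cc4)cn3c2)cc1` is not yet measured. It differs from compound 3 by trifluoromethyl in place of hydrogen on an aromatic carbon, on the same aromatic carbon that carries cyclohexyl in compound 1 and methyl in compound 2. Within the data shown here, the steps that bear on this change are the ones that strip that carbon: a 2.3-fold higher number from compound 1 to compound 3 (0.37 log units; beyond the scatter), a modest step, and a 1.9-fold higher number from compound 2 to compound 3 (0.29 log units; within the scatter), which stays within the scatter. Putting trifluoromethyl on that carbon is expected to run the other way and in about the size of those two steps, so a step of a 2.0-fold lower number from compound 3 to compound 4 (0.29 log units; within the scatter) is expected for compound 4 in this assay, a lower number than compound 3 without certainty of clearing the scatter. For compound 4 the estimate in this assay is 500 nM, with a range from 220 nM to 1100 nM.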

Compound 4, half-maximal effective concentration: 558 nM
Compound 4: middle estimate off by 1.1-fold (0.05 log units), on the low side; the measured number falls inside the stated range.
By their numbers in this assay, from the lowest: compounds 1, 2, 4 and 3 (each within the scatter of the next, the first and the last beyond it).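

In this assay, trifluoromethyl on this aromatic carbon gives a 1.8-fold lower number from compound 3 to compound 4 (0.24 log units; within the scatter), so this change on its own cannot be separated from hydrogen at this position, and the same holds for methyl, as the earlier step of a 1.9-fold higher number from compound 2 to compound 3 (0.29 log units; within the scatter) showed. The new compound also links the substituted members of the series: the readings of a 1.1-fold higher number from compound 2 to compound 4 (0.04 log units; within the scatter) and a 1.3-fold higher number from compound 1 to compound 4 (0.13 log units; within the scatter) place trifluoromethyl within the scatter of both methyl and cyclohexyl, so these three groups, which differ widely in size by heavy-atom count, are not resolved from one another on this carbon, and only cyclohexyl, with a 2.3-fold higher number from compound 1 to compound 3 (0.37 log units; beyond the scatter), stands clear of hydrogen. No measurement at hand accounts for this flat picture at the position.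

The compounds shown leave open how an amine, a hydroxyl or a carboxylic acid on this same aromatic carbon would read against the groups tested here. They also leave open whether trifluoromethyl on another carbon of this six-membered aromatic ring would give a step that clears the scatter.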